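The source may hold more compounds than are shown below. What is called first, only, known or untested is meant among the compounds shown, and "the series" means these compounds.

Working notes on the series. Compound 2 `COc1ccc2c(c1)c(/C=N\NC(=O)c1c[nH]c3ccccc13)cn2Cc1ccc(Cl)cc1` carries a hydrogen on the aromatic nitrogen of its acylhydrazone-bearing bicycle; in a functional assay on MDA-MB-231 cells (Homo sapiens) for cytotoxicity (on this read-out lower numbers stand for stronger inhibition and higher numbers for weaker inhibition), compound 2 gives 82700 nM. Compound 1 `COc1ccc2c(c1)c(/C=N\NC(=O)c1cn(C)c3ccccc13)cn2Cc1ccc(Cl)cc1` differs from it by methyl in place of hydrogen on an aromatic nitrogen. In this assay compound 1 gives only a limit, > 100000 nM, so the step of an at least 1.2-fold higher number from compound 2 to compound 1 (0.08 log units; that floor lies within the scatter) is known only by its floor, because of the limit of > 100000 nM in this assay, at which 1 of the 3 values shown sits. Compound 3 `O=C(N/N=C\c1cn(Cc2ccc(Cl)cc2)c2cc(F)ccc12)c1c[nH]c2ccccc12` has a different core; the difference between the two cores is not broken down here. In this assay compound 3 gives 5300 nM, the lowest of the two numbers measured. Compound 4 `Cn1cc(C(=O)N/N=C\c2cn(Cc3ccc(Cl)cc3)c3cc(F)ccc23)c2ccccc21` is not yet measured and differs from compound 3 by methyl in place of hydrogen on an aromatic nitrogen, the same change as that from compound 2 to compound 1. For compound 4 a step of a 2.8-fold higher number from compound 3 to compound 4 (0.45 log units; beyond the scatter) is expected, resting on the direction of the measured step of an at least 1.2-fold higher number from compound 2 to compound 1 (0.08 log units; that floor lies within the scatter) and on the limit hiding its full size. Compound 4 is thus estimated at 15000 nM in this assay, within 5000 nM to 60000 nM.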

Compound 4, half-maximal inhibitory concentration: > 100000 nM
Compound 4 gave a limit, no number; the forecaster's own chance of this, stated with the estimate: 15%; middle value at least 6.6-fold (0.82 log units) away from the limit.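

Carried to the core of compound 3, methyl in place of hydrogen on the aromatic nitrogen gives in this assay an at least 18-fold higher number from compound 3 to compound 4 (1.27 log units; beyond the scatter), so the direction that was only a floor within the scatter on the first pair is now beyond the scatter on a second core. This shows that the change does not lower the number on either of the two cores shown, but it does not show that the change has the same size on both, and two cores set no rule for others: the same change on two cores in this assay, an at least 1.2-fold higher number (0.08 log units; that floor lies within the scatter) from compound 2 to compound 1 and an at least 18-fold higher number (1.27 log units; beyond the scatter) from compound 3 to compound 4; the limit leaves it open whether they differ Compound 1 and compound 4 each give only a limit, so neither step has a known full size: the limit of > 100000 nM in this assay, at which 2 of the 4 values shown sit.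

The compounds shown leave open whether only methyl has this effect or any group in place of that hydrogen does. An ethyl group, a longer chain or an acetyl group on the same aromatic nitrogen, on a core where the parent gives a number well clear of the limit, would bear on that question.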